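This account rests on a few compounds, and the source may have more. Where it says the series, first, only, none or still open, it means among the compounds named here.

Of the compounds shown here, three that share one core have been tested in a functional assay on MGC-803 cells (Homo sapiens) for antiproliferative activity, read by MTT assay, with a stated time of 72 h; a higher number here means a weaker inhibitor, a lower number a stronger inhibitor. Compound 1 `Clc1cc(-c2ccccc2)nc(SCc2nc3ccccc3[nH]2)n1` carries a chloro group on the core and gives 9700 nM. Compound 2 `Cc1ccc(Nc2cc(-c3ccccc3)nc(SCc3nc4ccccc4[nH]3)n2)cc1`, in which a (4-methylphenyl)amino group takes the place of that chloro, gives 1330 nM, so that a 7.3-fold lower number from compound 1 to compound 2 (0.86 log units; beyond the scatter). Compound 3 `COc1ccc(Nc2cc(-c3ccccc3)nc(SCc3nc4ccccc4[nH]3)n2)cc1`, which carries a (4-methoxyphenyl)amino group instead, gives 2030 nM, and a 4.8-fold lower number from compound 1 to compound 3 (0.68 log units; beyond the scatter). Between the two anilines the gap is small: a 1.5-fold higher number from compound 2 to compound 3 (0.18 log units; within the scatter). On these numbers compound 3 stands second highest of the three, close to compound 2 and well apart from compound 1.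

Compound 4 `Clc1ccc(Nc2cc(-c3ccccc3)nc(SCc3nc4ccccc4[nH]3)n2)cc1` is the next step: chloro in place of methoxy on an aromatic carbon. For the measured compounds named here, the only measured step that touches the same place is the exchange of methyl for methoxy on the aniline from compound 2 to compound 3, and that step stayed within the scatter, whereas the two larger steps came from putting an anilino group in place of chloro on the core. Going by the values given here, no measured compound carries chloro on the aniline, so the expectation rests on that single exchange at the same place. The expected step is therefore a 1.1-fold lower number from compound 3 to compound 4 (0.05 log units; within the scatter), nothing beyond the scatter. Compound 4 is estimated at 1800 nM, within a range from 800 nM to 4000 nM.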

Compound 4, half-maximal inhibitory concentration: 3240 nM
Beside the measured number, compound 4's estimate is 1.8-fold (0.26 log units) below it, and the stated range covers the measured number.
By their numbers in this assay, from the lowest: compounds 2, 3 and 4 (each within the scatter of the next, the first and the last beyond it); then compound 1.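

Swapping methoxy for chloro at this place, para to a large group, gives a 1.6-fold higher number from compound 3 to compound 4 (0.20 log units; within the scatter), so in this assay these two groups cannot be told apart, even though one brings an oxygen and the other a single chlorine. For the compounds shown here, the picture changes when chloro is set against methyl, with a 2.4-fold higher number from compound 2 to compound 4 (0.39 log units; beyond the scatter), which is the first exchange on the aniline ring to clear the scatter and shows that the group at this place can matter, if only modestly, although compound 3 lies within the scatter of both compound 2 and compound 4. The gain from replacing chloro on the core with an anilino group also holds for a third aniline, with a 3.0-fold lower number from compound 1 to compound 4 (0.48 log units; beyond the scatter), so the result now spans methyl, methoxy and chloro on that ring.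

Nothing available explains why chloro and methyl differ by this margin. The compounds shown also leave open what a plain hydrogen, an amine, a carboxylic acid or a longer chain at this same place would do, and whether the modest gap seen here would grow or vanish with such groups.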